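The source may hold more compounds than are shown below. What is called first, only, known or untested is meant among the compounds shown, and "the series" means these compounds.

Compound 1 `O=C(/C=C1\CCc2cc(Cl)ccc21)NC1CC1`: 34%
Compound 2 `NC(=O)/C=C1\CCc2c(F)cccc21`: 40%
Compound 3 `CNC(=O)/C=C1\CCc2ccc(Br)cc21`: 44%

In a functional assay on the whole organism with Rattus norvegicus as the target, at a dose of 20 mg/kg by the oral route (a higher number here means more inhibition at the dose given (going by the name of the read-out), a lower number less inhibition), compound 1 gives the lowest of the three numbers, but compound 2 and compound 3 both lie within the usual scatter of it, so the three cannot be told apart on these measurements. Compound 4 `NC(=O)/C=C1\CCc2cc(Cl)ccc21` differs from compound 1 in a single place: hydrogen in place of cyclopropyl on an amide-type nitrogen. Among the measured compounds shown here, no two measured compounds differ in only one place, so there is no measured step to show what a change of this kind does in this assay. A step from compound 1 to compound 4 of a number 3 percentage points higher from compound 1 to compound 4 (within the scatter) is therefore expected, that is nothing clearly beyond the scatter. For compound 4 the estimate in this assay is 37%, with a range from 22% to 52%.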

Compound 4, a percentage reported as inhibition, in the whole organism at one dose (the size of the read-out at that dose, not a potency): 30%
For compound 4 the middle estimate is 7 percentage points above the measured one; measured number inside the range.
By their numbers in this assay, from the lowest: compounds 4, 1, 2 and 3 (each within the scatter of the next, the first and the last beyond it).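

In this assay, putting hydrogen in place of cyclopropyl on the amide-type nitrogen gives a number 4 percentage points lower from compound 1 to compound 4 (within the scatter). This is the first single-place comparison in the series, and it shows that, at this dose, the assay cannot tell these two groups apart at this position, so the cyclopropyl group is not shown to be needed there. No measurement available here bears on this result. Still open, on these data alone, is whether a longer chain on this nitrogen, or a chain ending in an amine or a carboxylic acid, would give a number clearly beyond the scatter.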